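The source may report more compounds than this note shows. Statements on the series, on what has been measured and on what is new or still open speak of the compounds shown alone.

Working notes on the sulfonyl-amide series. Compound 1 `O=C(NS(=O)(=O)c1ccccc1)c1ccc(Cl)nc1` gives 14100 nM in a functional assay on MCF7 cells (Homo sapiens) for antiproliferative activity, read by MTT assay, with a stated time of 48 h; on this read-out lower numbers stand for stronger inhibition and higher numbers for weaker inhibition. Compound 2 `Cc1ccc(S(=O)(=O)NC(=O)c2ccc(Cl)nc2)cc1` carries methyl in place of hydrogen on an aromatic carbon relative to compound 1, and in this assay compound 2 gives 17200 nM; the step is a 1.2-fold higher number from compound 1 to compound 2 (0.09 log units; within the scatter). Compound 3 `Cc1ccc(C(=O)NS(=O)(=O)c2ccccc2)c(Cl)n1` rests on a different core, and the difference between the two cores is not broken down here. In this assay compound 3 gives 13400 nM. Compound 4 `Cc1ccc(S(=O)(=O)NC(=O)c2ccc(C)nc2Cl)cc1` has not yet been measured; it differs from compound 3 by methyl in place of hydrogen on an aromatic carbon, the same change as from compound 1 to compound 2, at a place described in the same words. Among the compounds with values here, for compound 4 a step of about a 1.2-fold higher number from compound 3 to compound 4 (0.06 log units; within the scatter) in this assay is expected, because the one earlier instance of this change gave a 1.2-fold higher number from compound 1 to compound 2 (0.09 log units; within the scatter). Compound 4 is therefore estimated at 15500 nM in this assay, with an expected range from 7500 nM to 32000 nM.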

Compound 4, half-maximal inhibitory concentration: 8520 nM
Compound 4: the middle estimate sits 1.8-fold (0.26 log units) above what was measured; the range from low to high includes it.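

In this assay methyl in place of hydrogen on an aromatic carbon now gives a 1.6-fold lower number from compound 3 to compound 4 (0.20 log units; within the scatter). Set beside the earlier instance, the two steps do not separate: the same change on two cores in this assay, a 1.2-fold higher number (0.09 log units; within the scatter) from compound 1 to compound 2 and a 1.6-fold lower number (0.20 log units; within the scatter) from compound 3 to compound 4, 1.9-fold (0.28 log units) apart, within the scatter of two such steps. The change, phenyl to 4-methylphenyl, therefore stays within the scatter on both cores, but two such small steps do not show that it has a consistent direction or any real effect on either core.

The compounds shown leave open whether a different group at this place, such as methoxy, an amine or a carboxylic acid, would give a step beyond the scatter. They also leave open how the methyl change behaves on any further core.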